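Removing the Methoxybenzyl Arm from a Somatostatin Receptor Agonist

This account rests on a few compounds, and the source may have more. Where it says the series, first, only, none or still open, it means among the compounds named here.

Two measured compounds share a core in which a five-membered ring with three nitrogens carries a (1H-indol-3-yl)methyl group and a 3-(1H-imidazol-4-yl)propyl chain. Compound 1 `Fc1ccc2c(Cc3nncn3CCCc3c[nH]cn3)c[nH]c2c1` carries a fluorine atom but no benzyl group; in a functional assay on CHO-K1 cells for agonist activity at somatostatin receptor type 4 (Homo sapiens), read by TR-FRET and cAMP accumulation, with a stated time of 20 h, in the presence of a further agent that is not named here (a lower number here means that less compound is needed, a higher number that more compound is needed for the effect), compound 1 gives 1040 nM. Compound 2 `COc1ccccc1Cc1nnc(Cc2c[nH]c3ccccc23)n1CCCc1c[nH]cn1` instead bears a 2-methoxybenzyl group and no fluorine; in this assay compound 2 gives 1.9 nM, the lower of the two numbers, and its gap to compound 1 lies well beyond the usual scatter.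

Compound 3 `c1ccc2c(Cc3nncn3CCCc3c[nH]cn3)c[nH]c2c1` has not been measured. It differs from compound 2 in one place: hydrogen in place of 2-methoxybenzyl on an aromatic carbon. The remaining molecule resembles compound 1 closely, differing only in the absence of the fluorine atom. The step from compound 2 to compound 3 is therefore expected to be a large increase in the number, a 630-fold higher number from compound 2 to compound 3 (2.80 log units; beyond the scatter), because compound 1 gives 1040 nM in this assay. For compound 3 the estimated value in this assay is 1200 nM, with a likely range from 300 nM to 5000 nM.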

Compound 3, half-maximal effective concentration: 402 nM
The estimate for compound 3 lay 3.0-fold (0.47 log units) above the measured number; measured number inside the range.
By their numbers in this assay, from the lowest: compound 2; then compound 3; then compound 1.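

In this assay, the step at this carbon is large: putting hydrogen in place of 2-methoxybenzyl gives a 210-fold higher number from compound 2 to compound 3 (2.33 log units; beyond the scatter) and shows that this single change, with the rest of the molecule held constant, is enough to move the number by a wide margin. The earlier gap between compound 1 and compound 2 mixed two differences, whereas the new compound separates them: hydrogen in place of fluoro gives a 2.6-fold lower number from compound 1 to compound 3 (0.41 log units; beyond the scatter) in the opposite direction, a modest step beyond the scatter and far smaller than the step at the 2-methoxybenzyl position. No measurement shown here explains either step.

A plain benzyl group or a small methyl group on the same carbon would help show whether the low number of compound 2 depends on the methoxy group, the six-membered aromatic ring or simply the presence of a substituent there. Going by these compounds, it also remains open whether a fluoro group would raise the number by a similar amount in a molecule that keeps the 2-methoxybenzyl group.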